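The compounds below may be only part of what the source reports. "The series", "measured", "known", "first", "only" and "open" are said of these compounds alone.

Compound 3 `COc1ccc(/C=C(\C(=O)c2ccc(Cl)cc2)S(=O)(=O)c2ccc(C)cc2)cc1O` and compound 1 `COc1ccc(/C=C(/Sc2ccc(C)cc2)C(=O)c2ccc(Cl)cc2)cc1O` share one core. In a functional assay on DU-145 cells (Homo sapiens) for inhibition, read by trypan blue exclusion, with a stated time of 96 h (on this read-out higher numbers stand for weaker inhibition of growth and lower numbers for stronger inhibition of growth), compound 3 gives 1000 nM and compound 1 gives 1000 nM. The change between them is (4-methylphenyl)sulfanyl in place of (4-methylphenyl)sulfonyl on a double-bonded chain carbon bound to a carbonyl carbon and a double-bonded chain carbon, and its step is no change at the digits printed from compound 3 to compound 1 (within the scatter). Compound 2 `Cc1ccc(S(=O)(=O)/C(=C/c2ccc(Oc3ccccc3)cc2)C(=O)c2ccc(Cl)cc2)cc1` has a different core; how the two cores differ is not broken down here. In this assay compound 2 gives 1000 nM, level with compounds 1 and 3 within the scatter. Compound 4 `Cc1ccc(S/C(=C/c2ccc(Oc3ccccc3)cc2)C(=O)c2ccc(Cl)cc2)cc1` is not yet measured. It arises from compound 2 by (4-methylphenyl)sulfanyl in place of (4-methylphenyl)sulfonyl on a double-bonded chain carbon bound to a carbonyl carbon and a double-bonded chain carbon, the same change at the same place as from compound 3 to compound 1. The step from compound 2 to compound 4 is expected to be no change at the digits printed from compound 2 to compound 4 (within the scatter), resting on the earlier step from compound 3 to compound 1, which lay within the scatter. In this assay compound 4 is therefore estimated at 1000 nM, probably between 500 nM and 2000 nM.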

Compound 4, concentration for 50% growth inhibition: 10000 nM
Estimate against measurement, compound 4: 10-fold (1.00 log units) below, outside the stated range (above it).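

In this assay, putting (4-methylphenyl)sulfanyl in place of (4-methylphenyl)sulfonyl gives a 10-fold higher number from compound 2 to compound 4 (1.00 log units; beyond the scatter). The same change therefore does not carry over unchanged from one core to the other: the same change on two cores in this assay, no change at the digits printed (within the scatter) from compound 3 to compound 1 and a 10-fold higher number (1.00 log units; beyond the scatter) from compound 2 to compound 4, 10-fold (1.00 log units) apart, beyond the scatter of two such steps. This shows that, for these two pairs, the result of the change depends on the core it is made on, but it does not show which part of the cores matters, and two pairs give no general rule for the series.

Still open, going by these compounds, is how the change would behave on any further core. Also open, on these data alone, is how a (4-methylphenyl)sulfinyl group or an amine would compare on the same double-bonded chain carbon.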